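Propyl to Isopropyl Ester on Two Related Cores

The compounds below may be only part of what the source reports. "The series", "measured", "known", "first", "only" and "open" are said of these compounds alone.

Compound 1 `CCCOC(=O)c1c(NC(=S)Nc2cccc3ccccc23)sc2c1CCC2` and compound 3 `CC(C)OC(=O)c1c(NC(=S)Nc2cccc3ccccc23)sc2c1CCC2` share one core and differ by isopropyl in place of propyl on an oxygen next to a carbonyl group. In an assay on HEK-Blue hTLR2 cells for agonist activity at Toll-like receptor 2 (Homo sapiens), with a stated time of 24 h (on this read-out higher numbers stand for an effect only at larger amounts of compound and lower numbers for an effect already at smaller amounts), compound 1 gives 820 nM, while compound 3 gives 180 nM; this change produced a 4.6-fold lower number from compound 1 to compound 3 (0.66 log units; beyond the scatter). Compound 2 `CCCOC(=O)c1c(NC(=S)Nc2cccc3ccccc23)sc2c1CCCC2` carries the propyl ester on a second core; how the two cores differ is not broken down here. In this assay compound 2 gives 1050 nM, within the scatter of compound 1. Compound 4 `CC(C)OC(=O)c1c(NC(=S)Nc2cccc3ccccc23)sc2c1CCCC2` is not yet measured and differs from compound 2 by isopropyl in place of propyl on an oxygen next to a carbonyl group, the same change at the same place as between compound 1 and compound 3. A step of similar size is expected for compound 4, a 4.6-fold lower number from compound 2 to compound 4 (0.66 log units; beyond the scatter), because the earlier change gave a 4.6-fold lower number from compound 1 to compound 3 (0.66 log units; beyond the scatter) and because compound 2 gives 1050 nM. Compound 4 is therefore estimated at 230 nM in this assay, expected between 100 nM and 600 nM.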

Compound 4, half-maximal effective concentration: 140 nM
Compound 4: middle estimate off by 1.6-fold (0.22 log units), on the high side, and the stated range covers the measured number.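

On the second core, isopropyl in place of propyl again lowers the number in this assay, giving a 7.5-fold lower number from compound 2 to compound 4 (0.88 log units; beyond the scatter) and so repeating the direction seen on the first core. Set beside the earlier step, the size of the change also carries over as far as repeated measurements can tell: the same change on two cores in this assay, a 4.6-fold lower number (0.66 log units; beyond the scatter) from compound 1 to compound 3 and a 7.5-fold lower number (0.88 log units; beyond the scatter) from compound 2 to compound 4, 1.6-fold (0.22 log units) apart, within the scatter of two such steps. This supports transfer between these two cores only; it does not show that the step would hold on any further core, nor why the isopropyl ester gives the lower number.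

The compounds shown leave open how a longer chain, such as a butyl ester, or a branched tert-butyl ester would compare. They also leave open where an amide or a carboxylic acid in place of the ester would stand.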